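Trimming the Chain Further in Compound 3

A few compounds are considered here, and "the series" means these few. Any claim that something is new, unique, unknown or untested is made for them only; others in the source may bear on it.

In a functional assay on A549 cells (Homo sapiens) for antiproliferative activity, read by CCK-8 assay, with a stated time of 72 h (on this read-out higher numbers stand for weaker inhibition and lower numbers for stronger inhibition), compound 1 `CCOc1cc(C(C)(C)C)ccc1C1=NC(c2ccc(Cl)cc2)C(c2ccc(Cl)cc2)N1C(=O)NCCCCCCCC(=O)Nc1ccccc1N` gives 15200 nM and compound 2 `CCOc1cc(C(C)(C)C)ccc1C1=NC(c2ccc(Cl)cc2)C(c2ccc(Cl)cc2)N1C(=O)NCCCCCCC(=O)Nc1ccccc1N` gives 16000 nM so the two values lie within the scatter of each other. For the measured compounds named here, the one measured step of a 1.1-fold higher number from compound 1 to compound 2 (0.02 log units; within the scatter) stays within the scatter and shortens the same chain. Compound 3 `CCOc1cc(C(C)(C)C)ccc1C1=NC(c2ccc(Cl)cc2)C(c2ccc(Cl)cc2)N1C(=O)NCCCCC(=O)Nc1ccccc1N` goes further along that line with (2-aminophenyl)carbamoyl in place of 2-((2-aminophenyl)carbamoyl)ethyl on a saturated chain carbon, four bonds along the chain from an amide-type nitrogen and so carries (2-aminophenyl)carbamoyl in place of 2-((2-aminophenyl)carbamoyl)ethyl on a saturated chain carbon, four bonds along the chain from an amide-type nitrogen. This change is larger than the measured one, so that single flat step is thin support, yet no step beyond the scatter is expected in this assay on present evidence. The expected step is a 1.1-fold lower number from compound 2 to compound 3 (0.03 log units; within the scatter) and no direction is favoured. Compound 3 is estimated at 15000 nM with 7000 nM to 32000 nM as the expected range.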

Compound 3, half-maximal inhibitory concentration: 18400 nM
Compound 3: middle estimate off by 1.2-fold (0.09 log units), on the low side; measured number inside the range.
By their numbers in this assay, from the lowest: compounds 1, 2 and 3 (each within the scatter of the next).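

The replacement of 2-((2-aminophenyl)carbamoyl)ethyl by (2-aminophenyl)carbamoyl on a saturated chain carbon, four bonds along the chain from an amide-type nitrogen, gives a 1.2-fold higher number from compound 2 to compound 3 (0.06 log units; within the scatter) in this assay and so stays within the scatter. This shows that a larger cut at this position than the earlier step also leaves no readable difference, so both steps along this chain are flat in this read-out. No measured evidence here explains this flatness.

As far as these compounds go, whether a still shorter chain, or a hydroxamic acid in place of the 2-aminophenyl amide, would move the number beyond the scatter remains open. The compounds shown also leave open whether an ether oxygen within the chain would change this flat picture.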